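Compound 3 to compound 4: a step among limits

This account rests on a few compounds, and the source may have more. Where it says the series, first, only, none or still open, it means among the compounds named here.

In an ADME assay on HEK-293T cells (Homo sapiens) for cytotoxicity, read by CCK-8 assay, with a stated time of 48 h (a higher number here means a weaker inhibitor, a lower number a stronger inhibitor), compound 1 `Cc1cc(C)cc(NC(=O)NCCNS(=O)(=O)c2ccc(-c3ccccc3Oc3ccc([N+](=O)[O-])c([N+](=O)[O-])c3)s2)c1` gives only a limit, > 50000 nM and no number. Compound 2 `Cc1cc(C)cc(NC(=O)NCCNS(=O)(=O)c2ccc(-c3ccccc3OCc3ccccc3)s2)c1` also gives only a limit, > 20000 nM and no number. Within the data shown here, compound 3 `Cc1cc(C)cc(NC(=O)NCCNS(=O)(=O)c2ccc(-c3ccccc3OCc3cccc(O)c3)s2)c1` likewise stands at a limit, > 20000 nM and no number, as do all values so far. Among the measured compounds shown here, compound 4 `Cc1cc(C)cc(NC(=O)NCCNS(=O)(=O)c2ccc(-c3ccccc3Oc3ccc(N)cc3)s2)c1` carries 4-aminophenyl in place of 3-hydroxybenzyl on an oxygen on an aromatic ring as its single change. Changes at that oxygen are seen in a step that the two limits leave unreadable from compound 1 to compound 2 and in a step that the two limits leave unreadable from compound 1 to compound 3 while the hydroxy alone appears in a step that the two limits leave unreadable from compound 2 to compound 3 without a readable size. No step beyond the scatter, in either direction, is therefore expected in this assay here. The expected move is a step that the limit leaves unreadable from compound 3 to compound 4 and remains tentative. For compound 4 the estimate is 30000 nM with an estimated range of 10000 nM to 60000 nM overall.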

Compound 4, half-maximal inhibitory concentration: > 20000 nM
Compound 4 gave a limit, no number (the forecaster's own chance of this, stated with the estimate: 65%); the middle value is on the limit's open side.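

In this assay compound 4 gives > 20000 nM, a limit and not a number. Its steps from compound 1, compound 2 and compound 3 cannot be read. The compounds shown leave open whether any group on this oxygen changes the half-maximal inhibitory concentration.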